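This account rests on a few compounds, and the source may have more. Where it says the series, first, only, none or still open, it means among the compounds named here.

Going by the values given here, in an ADME assay on HepG2 cells (Homo sapiens) for cytotoxicity, read by MTT assay, with a stated time of 24 h (a lower number here means that less compound is tolerated, a higher number that more compound is tolerated), compound 2 `COc1ccc(-n2cc(COC3=C(CC=C(C)C)C(=O)c4ccccc4C3=O)nn2)c([N+](=O)[O-])c1` gives 532000 nM, the higher of the two numbers so far, while compound 1 `CC(C)=CCC1=C(OCc2cn(-c3ccccc3)nn2)C(=O)c2ccccc2C1=O` gives 100000 nM. Compound 3 `CC(C)=CCC1=C(OCc2cn(-c3ccccc3C)nn2)C(=O)c2ccccc2C1=O` carries 2-methylphenyl in place of 4-methoxy-2-nitrophenyl on an aromatic nitrogen. Among the compounds with values here, the one measured step that bears on this is a 5.3-fold higher number from compound 1 to compound 2 (0.73 log units; beyond the scatter), which introduced the 4-methoxy-2-nitrophenyl group in place of phenyl. Within the data shown here, no measurement yet covers 2-methylphenyl, but removing that group should largely reverse this modest step. The estimate is therefore an expected 4.1-fold lower number from compound 2 to compound 3 (0.61 log units; beyond the scatter). For compound 3 the expected value is 130000 nM, with an estimated range from 50000 nM to 340000 nM.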

Compound 3, half-maximal cytotoxic concentration: 256000 nM
Compound 3: the middle estimate sits 2.0-fold (0.29 log units) below what was measured, and the stated range covers the measured number.
By their numbers in this assay, from the lowest: compound 1; then compound 3; then compound 2.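

In this assay, a single methyl on the phenyl group is enough to shift the number: methyl in place of hydrogen gives a 2.6-fold higher number from compound 1 to compound 3 (0.41 log units; beyond the scatter). Replacing 4-methoxy-2-nitrophenyl with 2-methylphenyl gives a 2.1-fold lower number from compound 2 to compound 3 (0.32 log units; beyond the scatter), so a group of carbon alone keeps part of the rise seen with the larger group. The data offer no explanation for either step. On these data alone, it remains open whether the methoxy or the nitro group matters more in 4-methoxy-2-nitrophenyl. As far as these compounds go, how an amine or a carboxylic acid on this phenyl ring would compare also remains open.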